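Shortening an amide chain at an aromatic nitrogen

The source may hold more compounds than are shown below. What is called first, only, known or untested is meant among the compounds shown, and "the series" means these compounds.

Measured compounds:
Compound 1, `NCc1ccc(-n2cc(-c3ccc4cc[nH]c4c3)c(C(F)(F)F)n2)cc1`, gives 30 nM in an assay on isolated protein for inhibition of Myeloperoxidase (Homo sapiens); on this read-out lower numbers stand for stronger inhibition and higher numbers for weaker inhibition.
Compound 2, `NC(=O)CCn1cc(-c2ccc3cc[nH]c3c2)c(C(F)(F)F)n1`, gives 4200 nM in this assay.

Among the measured compounds shown here, of these two numbers, compound 2 holds the higher one, meaning the weaker inhibition; the only measured step is a 140-fold higher number from compound 1 to compound 2 (2.15 log units; beyond the scatter), so compound 2 sits well apart from compound 1.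

Compound 3, `NC(=O)Cn1cc(-c2ccc3cc[nH]c3c2)c(C(F)(F)F)n1`, is the next change on compound 2: carbamoyl in place of carbamoylmethyl on a saturated chain carbon bound to an aromatic nitrogen. The chain that carries the amide thus becomes one carbon shorter while the amide itself stays.

For the measured compounds named here, no measured pair shows what shortening this chain does. Going by the values given here, the one step that exists, a 140-fold higher number from compound 1 to compound 2 (2.15 log units; beyond the scatter), compares an aromatic substituent with a chain and says nothing about chain length. In the absence of any relevant comparison, the expectation for compound 3 is a number close to that of compound 2, with no step beyond the scatter in this assay in either direction, and the estimated step is a 1.1-fold lower number from compound 2 to compound 3 (0.02 log units; within the scatter). Compound 3 is therefore expected to give about 4000 nM, within a range of 1300 nM to 12000 nM, in this assay.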

Compound 3, half-maximal inhibitory concentration: 2000 nM
Compound 3: the middle estimate sits 2.0-fold (0.30 log units) above what was measured; measured number inside the range.
By their numbers in this assay, from the lowest: compound 1; then compound 3; then compound 2.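

Among the compounds shown here, for the first time, the length of the chain on the aromatic nitrogen can be read on its own. In this assay, going from 2-carbamoylethyl to carbamoylmethyl gives a 2.1-fold lower number from compound 2 to compound 3 (0.32 log units; beyond the scatter), so removing one chain carbon while keeping the amide brings a modest but real gain in inhibition. That gain closes only a small part of the gap to the aromatic substituent, as a 67-fold higher number from compound 1 to compound 3 (1.82 log units; beyond the scatter) shows, so 4-(aminomethyl)phenyl remains far ahead of both amide chains, and no measurement here explains why the shorter chain gives the lower number.

As far as these compounds go, two chain lengths give only two points, so it remains open whether a longer chain carrying the same amide would weaken inhibition further, or whether the effect of length would change if a carboxylic acid or an amine replaced the amide at the chain end. From the compounds shown here alone, it is also open which part of the 4-(aminomethyl)phenyl group matters most, and a plain phenyl group or a short aminoethyl chain on the same nitrogen would help to separate the ring from the amine.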